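Turning one double bond in compound 2

This account rests on a few compounds, and the source may have more. Where it says the series, first, only, none or still open, it means among the compounds named here.

Of the compounds shown here, three have been read so far in a functional assay on HL-60 cells (Homo sapiens), with a stated time of 48 h; on this read-out higher numbers stand for an effect only at larger amounts of compound and lower numbers for an effect already at smaller amounts. Compound 1 `CC1(C)CCC(C)(C)c2cc(/C=C/c3cccc(N)c3)ccc21` gives 40000 nM in this test. Compound 3 `COc1ccc(/C=C(\C)c2ccc3c(c2)C(C)(C)CCC3(C)C)cc1N` gives 40000 nM, the same reading. Compound 2 `C/C(=C\c1cccc(C(=O)O)c1)c1ccc2c(c1)C(C)(C)CCC2(C)C` gives > 100000 nM, which is a limit of the assay and not a number. That places compound 2 at the limit of > 100000 nM in this assay, at which 1 of the 3 values shown sits. So two of the three compounds have a real number, while compound 2 has only a limit.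

The next compound to be read is compound 4 `C/C(=C/c1cccc(C(=O)O)c1)c1ccc2c(c1)C(C)(C)CCC2(C)C`, the partner of compound 2. The change is small on paper: the two compounds have the same atoms and bonds and differ only in configuration as drawn: 1 of 1 stereo elements differ; a double bond is drawn E in compound 2 and Z in compound 4. Nothing leaves and nothing enters, so any difference in the reading would come from that one double bond alone.

Among the compounds with values here, no measured pair in this set shows what such a change does, so there is no direct precedent to draw on. The expectation therefore rests on compound 2, with its reading of > 100000 nM. The expected step, a number no higher from compound 2 to compound 4 (the limit leaves the size open), is none beyond the usual scatter, and the assay may well report only a limit again. For compound 4 the estimated value is 100000 nM, with an expected range of 30000 nM to 200000 nM.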

Compound 4, concentration for half-maximal activity: 80000 nM
The estimate for compound 4 lay 1.3-fold (0.10 log units) above the measured number; the measured number falls inside the stated range.
By their numbers in this assay, from the lowest: compounds 1, 3 and 4 (each within the scatter of the next). At a limit, above all of these: compound 2.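

Within the data shown here, compounds 2 and 4 are the first pair in this set to show what turning this double bond does, and in this assay the change from E to Z gives an at least 1.2-fold lower number from compound 2 to compound 4 (0.09 log units; that floor lies within the scatter). Compound 2 carries only a limit of the assay and not a number, so this step marks a floor and not a measured size: the limit of > 100000 nM in this assay, at which 1 of the 4 values shown sits. This floor does not establish a real effect of the turn, but whatever gap exists between the two readings belongs to the double bond alone, with no group lost or gained: the fact that compounds 2 and 4 differ only in the configuration as drawn.

As far as these compounds go, the true size of the step stays open, and with it the question of whether turning this double bond moves the reading beyond the usual scatter at all. Also open, from the compounds shown here alone, is whether the same turn would behave in the same way with a methyl ester or an amide in place of the carboxylic acid, since this one pair speaks only for compounds that carry the acid.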